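Swapping Benzoyl for Pyridinylsulfonyl on a Shared Core

The source may report more compounds than this note shows. Statements on the series, on what has been measured and on what is new or still open speak of the compounds shown alone.

Compound 1 `C[C@@H](Cn1ccc(-c2ccc(C#N)c(Cl)c2)n1)NC(=O)c1ccccc1`: > 30000 nM
Compound 2 `C[C@@H](Cn1ccc(-c2ccc(C#N)c(Cl)c2)n1)NC(=O)c1cccc(OCC(O)CO)c1`: > 30000 nM

In an ADME assay on PC-3 cells (Homo sapiens) for cytotoxicity, read by CCK-8 assay, with a stated time of 6 days (on this read-out higher numbers stand for weaker inhibition and lower numbers for stronger inhibition), compound 1 gives > 30000 nM, which is a limit of the assay rather than a number. Compound 2 likewise gives > 30000 nM in this assay, again a limit. Within the data shown here, both values therefore sit at the limit of > 30000 nM in this assay, at which 2 of the 2 values shown sit, and the only step recorded, a step that the two limits leave unreadable from compound 1 to compound 2, cannot be read for size or direction. Compound 1 thus stands at the limit, with nothing to rank it against.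

Compound 3 `C[C@@H](Cn1ccc(-c2ccc(C#N)c(Cl)c2)n1)NS(=O)(=O)c1cccnc1` differs from compound 1 by (pyridin-3-yl)sulfonyl in place of benzoyl on an amine nitrogen. Among the measured compounds shown here, no measured step covers this exchange, and the one step recorded between measured compounds is unreadable, so nothing in the data points to a readable shift in either direction. For compound 3 the expectation is a value of about 40000 nM, within a range of 15000 nM to 100000 nM, most probably reported again as a limit. The step that the limit leaves unreadable from compound 1 to compound 3 is therefore expected to be none beyond the scatter.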

Compound 3, half-maximal inhibitory concentration: > 30000 nM
Compound 3 gave a limit, no number (the forecaster's own chance of this, stated with the estimate: 85%); the middle value lies beyond the limit too.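

Compound 1 and compound 3 both give only a limit, so the step between them cannot be read for size or direction. How far compound 1, compound 2 and compound 3 truly differ in this assay stays open, since all three stop at the same point: the limit of > 30000 nM in this assay, at which 3 of the 3 values shown sit.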